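The source may hold more compounds than are shown below. What is called first, only, known or untested is meant among the compounds shown, and "the series" means these compounds.

Compound 1, `COc1ccc(C(=O)Nc2c(C)cccc2Cl)cc1OC1CCCC1`: 100 nM
Compound 2, `CCCCOc1cc(C(=O)Nc2c(F)cccc2F)ccc1OC`: 300 nM
Compound 3, `COc1ccc(C(=O)Nc2ccccc2Cl)cc1OC`: 650 nM

All three were tested in an assay on isolated protein for inhibition of phosphodiesterase 4A (Sus scrofa); a lower number here means a stronger inhibitor, a higher number a weaker inhibitor. Compound 1 gives the lowest number of the three. Compound 2 comes nearest to it, yet the gap between them is already beyond the usual scatter of repeated measurements; compound 3 stands furthest away, with a still larger gap. Compound 1 is therefore the strongest inhibitor among the measured compounds.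

Compound 4, `COc1ccc(C(=O)Nc2c(C)nsc2C)cc1OC1CCCC1`, has not yet been measured. It differs from compound 1 in a single place: 3,5-dimethyl-1,2-thiazol-4-yl in place of 2-chloro-6-methylphenyl on an amide-type nitrogen. The rest of the molecule, the amide and the ring with its methoxy and cyclopentyloxy groups, is kept.

For the measured compounds named here, no pair of measured compounds differs in just one place, so no measured step shows what this kind of exchange does in this assay. The three values only show that the group on the amide nitrogen matters. The step from compound 1 to compound 4 is expected to be small, either within the scatter or a modest move toward a higher number, expected as a 2.0-fold higher number from compound 1 to compound 4 (0.30 log units; within the scatter). For compound 4 in this assay the estimated value is 200 nM, expected to fall between 40 nM and 1000 nM.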

Compound 4, half-maximal inhibitory concentration: 500 nM
The estimate for compound 4 lay 2.5-fold (0.40 log units) below the measured number; the measured number falls inside the stated range.
By their numbers in this assay, from the lowest: compound 1; then compounds 2, 4 and 3 (each within the scatter of the next, the first and the last beyond it).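

For the compounds shown here, with the rest of the molecule kept, putting 3,5-dimethyl-1,2-thiazol-4-yl in place of 2-chloro-6-methylphenyl on the amide nitrogen leads to a 5.0-fold higher number from compound 1 to compound 4 (0.70 log units; beyond the scatter) in this assay and gives the first reading of this position on its own. The group at this place matters by itself, and here the five-membered ring with two hetero atoms does not replace the six-membered carbon ring without a loss of strength, although the change is modest. Nothing available explains this loss.

The compounds shown do not tell whether a pyridyl ring or a plain phenyl ring on the amide nitrogen would come closer to compound 1. They also leave open whether this exchange would cost as much with a hexyloxy chain in place of the cyclopentyloxy group.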